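Chloro for Fluoro: Estimating Compound 4 Before Measurement

The compounds below may be only part of what the source reports. "The series", "measured", "known", "first", "only" and "open" are said of these compounds alone.

compound 1 `CSc1cccc(N2CCNC(=O)N2)c1`: 14000 nM
compound 2 `CCCCC1CN(c2ccccc2)NC(=O)N1`: 1500 nM
compound 3 `CC1CN(c2cccc(F)n2)NC(=O)N1`: 6600 nM

These three compounds were tested in an assay on RBL-1 cells for inhibition of Polyunsaturated fatty acid 5-lipoxygenase (Rattus norvegicus); on this read-out higher numbers stand for weaker inhibition and lower numbers for stronger inhibition. Compound 3 gives the second highest of the three numbers: compound 1 gives a higher number and compound 2 a lower one, both gaps beyond the usual scatter. Compound 4 `CC1CN(c2cccc(Cl)n2)NC(=O)N1` has not yet been measured. It differs from compound 3 in one place: chloro in place of fluoro on an aromatic carbon. Among the compounds with values here, no measured pair shows this same change, so its effect in this assay is uncertain; such a small swap is expected to move the number only a little, most likely within the scatter or slightly lower. Compound 4 is therefore estimated at 5000 nM, with a range from 2000 nM to 13000 nM. This estimate means an expected step of a 1.3-fold lower number from compound 3 to compound 4 (0.12 log units; within the scatter), modest in size.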

Compound 4, half-maximal inhibitory concentration: 3500 nM
The estimate for compound 4 lay 1.4-fold (0.15 log units) above the measured number; the measured number falls inside the stated range.
By their numbers in this assay, from the lowest: compound 2; then compounds 4 and 3 (each within the scatter of the next); then compound 1.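

In this assay, chloro in place of fluoro next to the ring nitrogen gives a 1.9-fold lower number from compound 3 to compound 4 (0.28 log units; within the scatter), so the two groups cannot be told apart at this position. Within the data shown here, this is the first pair here that differs in one place, which the earlier compounds could not provide. Nothing available explains this result. Still open, from the compounds shown here alone, is whether an amine, a methoxy group or a nitrile at this position would give a number beyond the scatter. Going by these compounds, the effect of a longer chain on this pyridine-bearing series also remains open.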